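The source may report more compounds than this note shows. Statements on the series, on what has been measured and on what is new or still open speak of the compounds shown alone.

Measured so far in an assay on isolated protein for inhibition of RAC-alpha serine/threonine-protein kinase (Homo sapiens), tested at 30 uM; on this read-out higher numbers stand for more inhibition at the one concentration tested (going by the name of the read-out) and lower numbers for less inhibition:
Compound 1 `Fc1ccc(Sc2ncnc3[nH]cnc23)cc1`: 0%
Compound 2 `Cn1cnc2c(Sc3ccccc3)ncnc21`: 0%

Compound 2 stands level with compound 1 at the digits shown, the difference lying within the scatter; neither compound shows inhibition in this assay. Compound 3 `Cn1cnc2c(Sc3ccc(F)cc3)ncnc21` differs from compound 2 by fluoro in place of hydrogen on an aromatic carbon. Compound 1 already carries the fluoro group and gives 0% in this assay, so no step beyond the scatter is expected here. The expected step of no change at the digits printed from compound 2 to compound 3 (within the scatter) is essentially none. Compound 3 is estimated at 0%, with a range from -8% to 10%.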

Compound 3, a percentage reported as inhibition, at one concentration (the size of the read-out at that concentration, not a potency): 0%
Compound 3: middle estimate and measured number agree at the digits printed; measured number inside the range.
By their numbers in this assay, from the lowest: compounds 1, 2 and 3 (each within the scatter of the next).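

In this assay the reading shows no change at the digits printed from compound 2 to compound 3 (within the scatter) for fluoro in place of hydrogen on an aromatic carbon, para to a large group, and no change at the digits printed from compound 1 to compound 3 (within the scatter) for methyl in place of hydrogen on an aromatic nitrogen. Neither single change separates these compounds at the one concentration tested. No measurement offers an explanation for this result.

From the compounds shown here alone, whether an amine or a carboxylic acid at the fluoro position would give any inhibition remains open. With no inhibition in any compound shown, how either change acts on a compound that does inhibit also remains open.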